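The source may hold more compounds than are shown below. What is called first, only, known or untested is meant among the compounds shown, and "the series" means these compounds.

Compound 1 `Cc1cc(N2CC[C@@H](C)[C@@H](N(C)c3ncnc4[nH]ccc34)C2)n2nc(SCC3CC3)nc2n1` gives 36500 nM in a functional assay on BGC-823 cells (Homo sapiens) for inhibition, read by MTT assay, with a stated time of 72 h; on this read-out lower numbers stand for stronger inhibition and higher numbers for weaker inhibition.
Compound 2 `Cc1cc(N2CC[C@@H](C)[C@@H](N(C)c3ncnc4[nH]ccc34)C2)n2nc(SCCCc3ccccc3)nc2n1` gives > 100000 nM in this assay, which is a limit of the assay and not a number.

Among the measured compounds shown here, compound 1 is the only compound with a number in this assay; the one other value is a limit, (the limit of > 100000 nM in this assay, at which 1 of the 2 values shown sits). Compound 3 `C#CSc1nc2nc(C)cc(N3CC[C@@H](C)[C@@H](N(C)c4ncnc5[nH]ccc45)C3)n2n1` has not been measured. Set against compound 1, it carries ethynyl in place of cyclopropylmethyl on a sulfur, so the group on the sulfur becomes shorter and loses its ring. For the measured compounds named here, the only measured step, an at least 2.7-fold higher number from compound 1 to compound 2 (0.43 log units; beyond the scatter), went the other way in size, making the group on the sulfur larger, and how much weaker compound 2 really is cannot be told because compound 2 sits at the limit of > 100000 nM in this assay, at which 1 of the 2 values shown sits. Going by the values given here, no measured pair shows what shrinking the group does, so that step is a poor guide here. Compound 3 is expected to show a 1.1-fold higher number from compound 1 to compound 3 (0.04 log units; within the scatter), that is, no step beyond the scatter. Compound 3 is estimated at 40000 nM, with a range from 12000 nM to 100000 nM.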

Compound 3, half-maximal inhibitory concentration: 62100 nM
Compound 3: middle estimate off by 1.6-fold (0.19 log units), on the low side, within the range that was stated.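

In this assay, replacing cyclopropylmethyl on the sulfur with the shorter, ring-free ethynyl gives a 1.7-fold higher number from compound 1 to compound 3 (0.23 log units; within the scatter). Among the compounds shown here, this is the first look at a smaller group at this position, and it shows that removing the three-membered ring and shortening the group produces no change that can be told from the scatter. Against the much larger 3-phenylpropyl group, the comparison gives an at least 1.6-fold lower number from compound 2 to compound 3 (0.20 log units; that floor lies within the scatter), so even the smallest gap this allows stays within the scatter, and the true gap cannot be read because compound 2 carries a limit and not a number: the limit of > 100000 nM in this assay, at which 1 of the 3 values shown sits.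

The groups shown leave open whether anything on this sulfur can move the number well below that of compound 1, such as a plain methyl or a short chain ending in an amine or a carboxylic acid. Every compound shown also keeps the sulfur itself, so what an oxygen or a nitrogen in its place would do remains an open question.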